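Methyl in place of hydrogen on the benzoxazine ring

The compounds below may be only part of what the source reports. "The series", "measured", "known", "first", "only" and "open" are said of these compounds alone.

Measured compounds:
Compound 1 `O=c1cc(-c2ccccc2)oc2ccc(N3COc4c(cccc4[N+](=O)[O-])C3)cc12`: 72.9%
Compound 2 `O=c1cc(-c2ccccc2)oc2ccc(N3COc4ccccc4C3)cc12`: 92.7%
Compound 3 `Cc1cccc2c1OCN(c1ccc3oc(-c4ccccc4)cc(=O)c3c1)C2`: 85.1%

In a functional assay on MCF7 cells (Homo sapiens) for inhibition, read by MTT assay, with a stated time of 48 h, tested at 60 ug/mL (a higher number here means more inhibition of growth at the concentration tested, a lower number less inhibition of growth), compound 2 stands highest of the three numbers. Its nearest neighbour is compound 3, and the step of a number 7.6 percentage points lower from compound 2 to compound 3 (within the scatter) lies within the scatter, so the two cannot be put in order. Compound 1 is furthest away: a number 19.8 percentage points higher from compound 1 to compound 2 (beyond the scatter) and a number 12.2 percentage points higher from compound 1 to compound 3 (beyond the scatter) both lie beyond the scatter.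

Compound 4 `Cc1ccc2c(c1)CN(c1ccc3oc(-c4ccccc4)cc(=O)c3c1)CO2` has not yet been measured in this assay. It differs from compound 2 in one place: methyl in place of hydrogen on an aromatic carbon. The step that bears on this change is a number 7.6 percentage points lower from compound 2 to compound 3 (within the scatter), the same exchange of a methyl for a hydrogen on the same ring of the shared core, which stayed within the scatter. The steps from compound 1 concern the nitro group and do not speak to this change. The step of a number 5.7 percentage points lower from compound 2 to compound 4 (within the scatter) is therefore expected to be small and not beyond the scatter, perhaps slightly downward as with compound 3. Compound 4 is estimated to give 87% in this assay, with a range from 75% to 97%.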

Compound 4, percent growth inhibition at one concentration: 79.5%
Beside the measured number, compound 4's estimate is 7.5 percentage points above it; low and high end bracket the measured number.
By their numbers in this assay, from the lowest: compounds 1, 4, 3 and 2 (each within the scatter of the next, the first and the last beyond it).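

In this assay, going by these compounds alone, the exchange of hydrogen for methyl on this aromatic carbon, meta to a fused ring and para to a fused ring, gives a number 13.2 percentage points lower from compound 2 to compound 4 (beyond the scatter) and is the first methyl step to pass beyond the scatter. The same exchange on another carbon of the ring gave a number 7.6 percentage points lower from compound 2 to compound 3 (within the scatter) and so methyl in place of hydrogen cannot be read as a silent change everywhere on this ring, although compound 3 at 85.1% and compound 4 at 79.5% lie within the scatter of each other and the two places cannot be put in order. Nothing available here accounts for the lower number of compound 4.

The compounds shown leave open whether an ethyl, a methoxy or an amine on this same carbon would lower the number further, leave it as it is or restore it. They also leave open whether this step would persist across a range of concentrations, as each number here is a reading at one concentration.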